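The source may report more compounds than this note shows. Statements on the series, on what has been measured and on what is new or still open speak of the compounds shown alone.

Compound 1, `CC(=O)Nc1ccc(S(=O)(=O)NNc2ccccc2)cc1`: in an assay on HeLa cells for inhibition of Indoleamine 2,3-dioxygenase 1 (Homo sapiens), read by spectrophotometry, with a stated time of 24 h (on this read-out lower numbers stand for an effect already at smaller amounts and higher numbers for an effect only at larger amounts of compound), compound 1 gives > 10000 nM, which is a limit of the assay and not a number.
Compound 2, `CC(=O)Nc1ccc(S(=O)(=O)NNc2ccc(C)cc2)cc1`: in this assay compound 2 gives 1170 nM.
Compound 3, `COc1ccc(NNS(=O)(=O)c2ccc(NC(C)=O)cc2)cc1`: in this assay compound 3 gives > 10000 nM, again a limit of the assay rather than a number.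

Compound 3 therefore stands at the limit of > 10000 nM in this assay, at which 2 of the 3 values shown sit, so no number is known for it, only that any effect appears beyond what the assay covers. Compound 4 is `CC(=O)Nc1ccc(S(=O)(=O)NNc2ccc(C#N)cc2)cc1`; it differs from compound 3 by cyano in place of methoxy on an aromatic carbon.

Going by the values given here, two measured steps touch the same position. The change an at least 8.5-fold lower number from compound 1 to compound 2 (0.93 log units; beyond the scatter) shows that a methyl there moved the number well below the limit. The change an at least 8.5-fold higher number from compound 2 to compound 3 (0.93 log units; beyond the scatter) shows that a methoxy in place of that methyl sent the number back to the limit, and a step that the two limits leave unreadable from compound 1 to compound 3 cannot be read because both values are limits. None of the measured compounds carries a cyano, so the shown steps give no direction for compound 4; they show only that a small group at this position can matter a great deal in either direction.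

Compound 4 is therefore expected to lie near the limit, with the estimated step of an at least 1.6-fold lower number from compound 3 to compound 4 (0.22 log units; that floor lies within the scatter) carrying wide uncertainty. For compound 4 the estimate in this assay is 6000 nM, with a range from 1500 nM to 20000 nM.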

Compound 4, half-maximal effective concentration: 1390 nM
For compound 4 the middle estimate is 4.3-fold (0.64 log units) above the measured one, and the stated range ends above it.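

Placing a cyano on this aromatic carbon, para to a large group, gives an at least 7.1-fold lower number from compound 1 to compound 4 (0.85 log units; beyond the scatter) in this assay, so methyl is no longer the only group shown here that moves the number clear of the limit. Cyano and methoxy have the same count of heavy atoms and the same count of hydrogen-bond acceptors, yet exchanging one for the other gives an at least 7.1-fold lower number from compound 3 to compound 4 (0.85 log units; beyond the scatter), so in this small set those counts alone do not decide the outcome. Exchanging methyl for cyano gives a 1.2-fold higher number from compound 2 to compound 4 (0.07 log units; within the scatter), so these two groups, which differ by a triple bond, cannot be told apart in this assay.

From the compounds shown here alone, the steps that start from compound 1 and compound 3 give only a smallest possible size, and their true size stays unknown, since both compounds rest at a limit of the assay: the limit of > 10000 nM in this assay, at which 2 of the 4 values shown sit. Going by these compounds, it also stays open whether an amine, a carboxylic acid or a longer chain such as propyl on this carbon would behave like methyl and cyano or like methoxy.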